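The compounds below may be only part of what the source reports. "The series", "measured", "known", "first", "only" and "open" are said of these compounds alone.

In a functional assay on HL-60 cells (Homo sapiens) for antiproliferative activity, read by XTT assay, with a stated time of 72 h (on this read-out lower numbers stand for stronger inhibition and higher numbers for weaker inhibition), compound 2 `C#Cc1cn([C@@H]2O[C@H](CO)[C@@H](O)[C@H]2O)c2ncnc(OC)c12` gives 190 nM. One change, (thiophen-3-yl in place of ethynyl on an aromatic carbon), leads to compound 1 `COc1ncnc2c1c(-c1ccsc1)cn2[C@@H]1O[C@H](CO)[C@@H](O)[C@H]1O`, which in this assay gives 130 nM, a step of a 1.5-fold lower number from compound 2 to compound 1 (0.16 log units; within the scatter). A different change on the core, (methylsulfanyl in place of methoxy on an aromatic carbon), leads to compound 3 `C#Cc1cn([C@@H]2O[C@H](CO)[C@@H](O)[C@H]2O)c2ncnc(SC)c12`, which in this assay gives 50 nM, the lowest number of the three, the step being a 3.8-fold lower number from compound 2 to compound 3 (0.58 log units; beyond the scatter). Going by the values given here, compound 4 `CSc1ncnc2c1c(-c1ccsc1)cn2[C@@H]1O[C@H](CO)[C@@H](O)[C@H]1O` has not been measured; it differs from compound 3 by thiophen-3-yl in place of ethynyl on an aromatic carbon, the same change as the one separating compound 2 from compound 1, here made on the core of compound 3. For compound 4 in this assay the expected step is a 1.4-fold lower number from compound 3 to compound 4 (0.15 log units; within the scatter). That expectation rests on compound 2 and compound 1, whose step is a 1.5-fold lower number from compound 2 to compound 1 (0.16 log units; within the scatter) and lies within the scatter. Compound 4 is therefore estimated at 35 nM, with a range from 15 nM to 80 nM.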

Compound 4, half-maximal inhibitory concentration: 4590 nM
Estimate against measurement, compound 4: 130-fold (2.12 log units) below, outside the stated range (above it).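

In this assay, thiophen-3-yl in place of ethynyl gives a 92-fold higher number from compound 3 to compound 4 (1.96 log units; beyond the scatter), so this change does not carry from the core of compound 2 to the core of compound 3: the same change on two cores in this assay, a 1.5-fold lower number (0.16 log units; within the scatter) from compound 2 to compound 1 and a 92-fold higher number (1.96 log units; beyond the scatter) from compound 3 to compound 4, 130-fold (2.13 log units) apart, beyond the scatter of two such steps Read the other way, methylsulfanyl in place of methoxy gives a 35-fold higher number from compound 1 to compound 4 (1.55 log units; beyond the scatter), so that change also depends on the group already present: the same change on two cores in this assay, a 3.8-fold lower number (0.58 log units; beyond the scatter) from compound 2 to compound 3 and a 35-fold higher number (1.55 log units; beyond the scatter) from compound 1 to compound 4, 130-fold (2.13 log units) apart, beyond the scatter of two such steps The two changes therefore do not add up in compound 4, but this rests on only four compounds and does not show what causes the mismatch or whether it extends to other groups.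

The compounds shown leave open whether a phenyl ring or a furan-3-yl ring would behave like thiophen-3-yl alongside methylsulfanyl. They also leave open how a longer alkyne chain, such as prop-1-ynyl, would behave there.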